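A few compounds are considered here, and "the series" means these few. Any claim that something is new, unique, unknown or untested is made for them only; others in the source may bear on it.

Measured in a functional assay on Jurkat cells (Homo sapiens) for antiproliferative activity, read by MTT assay, with a stated time of 72 h; a higher number here means a weaker inhibitor, a lower number a stronger inhibitor:
- compound 1 `COc1cc(-n2ncnc2-c2ccc(C)cc2)cc(OC)c1OC`: 300 nM
- compound 2 `COc1cc(-n2ncnc2-c2cccc(Cl)c2)cc(OC)c1OC`: > 10000 nM (a limit of the assay, not a number)

Compound 2 has only a limit and no number of its own: the limit of > 10000 nM in this assay, at which 1 of the 2 values shown sits.

The next compound, compound 3 `COc1cc(-n2ncnc2-c2ccc(F)cc2)cc(OC)c1OC`, has not yet been measured. It keeps the shared core and has 4-fluorophenyl in place of 3-chlorophenyl on an aromatic carbon.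

Among the compounds with values here, only one measured step bears on this change. It is an at least 33-fold higher number from compound 1 to compound 2 (1.52 log units; beyond the scatter), where 3-chlorophenyl took the place of 4-methylphenyl, and it is large and beyond the scatter. By name, the 4-fluorophenyl of compound 3 resembles the 4-methylphenyl of compound 1, which gives 300 nM, more than the group it replaces. Fluorine is not methyl, however, and a single step is thin support, so full recovery cannot be assumed.

The expected change is an at least 10-fold lower number from compound 2 to compound 3 (1.00 log units; beyond the scatter), towards a lower number and a stronger inhibitor in this assay. For compound 3 the estimated value is 1000 nM, with an expected range from 150 nM to 6000 nM.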

Compound 3, half-maximal inhibitory concentration: > 10000 nM
Compound 3 ended at the assay's limit; the forecaster's own chance of this, stated with the estimate: 15%; middle value at least 10-fold (1.00 log units) away from the limit.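

In this assay compound 3 gives > 10000 nM, which is a limit of the assay and not a number. With fluoro in place of methyl as the only change, the result is an at least 33-fold higher number from compound 1 to compound 3 (1.52 log units; beyond the scatter), so keeping a group at the 4 position of the phenyl ring does not by itself keep the activity, and among these three compounds only the 4-methylphenyl of compound 1 gives a measured number. The step between compound 2 and compound 3 cannot be read, because neither compound has a number of its own: the limit of > 10000 nM in this assay, at which 2 of the 3 values shown sit.

From the compounds shown here alone, it remains open whether the drop seen with 3-chlorophenyl comes from the chlorine, from where it sits on the phenyl ring, or from the loss of the methyl, and a 4-chlorophenyl or a plain phenyl at the same place would help to separate these. Going by these compounds, it is also open whether the methyl is the best group here or whether a 4-ethylphenyl or a 4-methoxyphenyl would give a lower number than compound 1.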